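The compounds below may be only part of what the source reports. "The series", "measured", "known", "first", "only" and "open" are said of these compounds alone.

In a functional assay on PC-3 cells (Homo sapiens), read by MTT assay, with a stated time of 48 h (on this read-out higher numbers stand for weaker inhibition and lower numbers for stronger inhibition), compound 1 `CCN(CC)CCNC(=O)c1ccc(C(CC)(CC)c2ccc(OCC(O)C(C)(C)C)c(C)c2)n1CC` gives 220 nM, compound 2 `CCn1c(C(=O)NCC(OC)OC)ccc1C(CC)(CC)c1ccc(OCC(O)C(C)(C)C)c(C)c1` gives 14600 nM and compound 3 `C=CCN(C)C(=O)c1ccc(C(CC)(CC)c2ccc(OCC(O)C(C)(C)C)c(C)c2)n1CC` gives 25900 nM. Compound 3 therefore sits level with compound 2 within the scatter, the gap being a 1.8-fold higher number from compound 2 to compound 3 (0.25 log units; within the scatter), and far from compound 1, the gap being a 120-fold higher number from compound 1 to compound 3 (2.07 log units; beyond the scatter).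

The next structure is compound 4 `C#CC(C)OC(=O)c1ccc(C(CC)(CC)c2ccc(OCC(O)C(C)(C)C)c(C)c2)n1CC`, with (1-methylprop-2-yn-1-yl)oxy in place of allyl(methyl)amino on a carbonyl carbon. The other large step, a 66-fold higher number from compound 1 to compound 2 (1.82 log units; beyond the scatter), also removes the diethylamino group, and compound 4 lacks that group as well. Exchanging one group without it for another gave only a 1.8-fold higher number from compound 2 to compound 3 (0.25 log units; within the scatter). For the measured compounds named here, no measured compound carries the entering group, so this reading remains an extrapolation. No step beyond the scatter is therefore expected in this assay, and no direction is favoured. The expected step is a 1.3-fold lower number from compound 3 to compound 4 (0.11 log units; within the scatter). The estimate for compound 4 is 20000 nM, with an expected range of 8000 nM to 50000 nM.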

Compound 4, half-maximal inhibitory concentration: 38200 nM
The estimate for compound 4 lay 1.9-fold (0.28 log units) below the measured number, and the stated range covers the measured number.
By their numbers in this assay, from the lowest: compound 1; then compounds 2, 3 and 4 (each within the scatter of the next, the first and the last beyond it).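

At this carbonyl carbon, the link through oxygen in (1-methylprop-2-yn-1-yl)oxy and the link through nitrogen in allyl(methyl)amino cannot be told apart in this assay (a 1.5-fold higher number from compound 3 to compound 4 (0.17 log units; within the scatter)), so the exchange of linking atom leaves the number within the scatter for this pair. The modest step of a 2.6-fold higher number from compound 2 to compound 4 (0.42 log units; beyond the scatter) and the large step of a 170-fold higher number from compound 1 to compound 4 (2.24 log units; beyond the scatter) extend the earlier picture: of the four groups on this carbon, only the (2-(diethylamino)ethyl)amino group of compound 1 goes with a low number. Nothing available explains these steps.

Open, going by these compounds, is whether the low number needs the diethylamino group itself or any amine at the chain end, such as dimethylamino or morpholine. Also open, on these data alone, is whether a 2-(diethylamino)ethoxy group on the carbonyl carbon would keep that low number.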